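The source may report more compounds than this note shows. Statements on the series, on what has been measured and on what is new or still open speak of the compounds shown alone.

Measured so far in an assay on Sf9 cells for inhibition of histone deacetylase 11 (Homo sapiens), read by fluorescence, tested at 0.5 uM; a lower number here means less inhibition, a higher number more inhibition at the concentration tested (going by the name of the read-out):
compound 1 `O=C(NO)c1ccc(-c2cn([C@H]3C[C@H](CO)N(CCCc4ccccc4)C3)nn2)cc1` gives 18%.
compound 2 `O=C(NO)c1ccc(-c2cn([C@@H]3C[C@@H](CO)N(Cc4ccccc4)C3)nn2)cc1` gives < 10%, which is a limit of the assay and not a number.

Compound 2 thus sits at the limit of < 10% in this assay, at which 1 of the 2 values shown sits. Compound 3 `O=C(NO)c1ccc(-c2cn([C@H]3C[C@H](CO)N(Cc4ccccc4)C3)nn2)cc1` is its mirror image: the two compounds have the same atoms and bonds and differ only in configuration as drawn: 2 of 2 stereo elements differ (all stereocentres are inverted: mirror images); a stereocentre at a saturated ring carbon is drawn R in compound 2 and S in compound 3; a stereocentre at a saturated ring carbon is drawn S in compound 2 and R in compound 3. For the measured compounds named here, no step between measured compounds is available to size such a change, so the expectation rests only on the two values shown. From the limit of compound 2 a small rise is estimated, a number at least 3 percentage points higher from compound 2 to compound 3 (that floor lies within the scatter), though a flat result within the scatter is equally plausible. Compound 3 is expected to give 13%, with a range from 4% to 25%.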

Compound 3, a percentage reported as inhibition, at one concentration (the size of the read-out at that concentration, not a potency): 16%
The estimate for compound 3 lay 3 percentage points below the measured number; the measured number falls inside the stated range.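

Inverting both stereocentres gives a number at least 6 percentage points higher from compound 2 to compound 3 (that floor lies within the scatter), the first read on configuration in this series, and the step rests on configuration alone: the fact that compounds 2 and 3 differ only in the configuration as drawn. In this assay compound 2 gives < 10%, a limit of the assay and not a number. With the configuration of compound 1 kept, phenyl in place of phenethyl gives a number 2 percentage points lower from compound 1 to compound 3 (within the scatter), so this chain change shows no effect beyond the scatter.

Open, from the compounds shown here alone, is the mirror image of compound 1, which would show whether configuration matters with the phenethyl group in place. Also open, going by these compounds, is whether an amine or a carboxylic acid on the chain on the ring nitrogen would shift the inhibition read-out.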